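A few compounds are considered here, and "the series" means these few. Any claim that something is new, unique, unknown or untested is made for them only; others in the source may bear on it.

Compounds measured in a functional assay on PC-3 cells (Homo sapiens) for cytotoxicity, read by MTT assay, with a stated time of 72 h; a higher number here means a weaker inhibitor, a lower number a stronger inhibitor:
compound 1 `COc1ccc(C(=O)c2cc(OC)c(OC)c(OC)c2)cc1NC(=O)/C=C/c1ccc(OC)c(OC)c1`, 7500 nM
compound 2 `COc1cccc(/C=C/C(=O)Nc2cc(C(=O)c3cc(OC)c(OC)c(OC)c3)ccc2OC)c1`, 4700 nM
compound 3 `COc1ccc(/C=C/C(=O)Nc2cc(C(=O)c3cc(OC)c(OC)c(OC)c3)cc(OC)c2OC)cc1OC`, 5400 nM

Among these three, compound 3 stands second highest, but compound 2 and compound 3 lie within the scatter of each other, and the step of a 1.4-fold lower number from compound 1 to compound 3 (0.14 log units; within the scatter) is within the scatter as well. Compound 4 `C#CCOc1cccc(/C=C/C(=O)Nc2cc(C(=O)c3cc(OC)c(OC)c(OC)c3)cc(OC)c2OC)c1` has not been measured. It differs from compound 3 by 3-(propargyloxy)phenyl in place of 3,4-dimethoxyphenyl on a double-bonded chain carbon bound to a double-bonded chain carbon. The measured step that bears most on this change is a 1.6-fold lower number from compound 1 to compound 2 (0.20 log units; within the scatter), which also removes one methoxy from that ring and stayed within the scatter; the step of a 1.4-fold lower number from compound 1 to compound 3 (0.14 log units; within the scatter) concerns a different ring. Going by the values given here, no measured compound carries a propargyloxy group, so that part of the change is uncharted. Compound 4 is therefore expected to show no step beyond the scatter, a 1.1-fold lower number from compound 3 to compound 4 (0.03 log units; within the scatter), with an estimated 5000 nM and a range of 2000 nM to 15000 nM in this assay.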

Compound 4, half-maximal inhibitory concentration: 10100 nM
Beside the measured number, compound 4's estimate is 2.0-fold (0.31 log units) below it; the measured number falls inside the stated range.
By their numbers in this assay, from the lowest: compounds 2, 3, 1 and 4 (each within the scatter of the next, the first and the last beyond it).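

In this assay, 3-(propargyloxy)phenyl in place of 3,4-dimethoxyphenyl on a double-bonded chain carbon bound to a double-bonded chain carbon gives a 1.9-fold higher number from compound 3 to compound 4 (0.27 log units; within the scatter). A group with a triple bond can therefore stand at this place without a step beyond the scatter, which the methoxy compounds could not show. No measurement here accounts for this step. The step combines the loss of a methoxy with the entry of the propargyloxy group, and these two parts remain unseparated. From the compounds shown here alone, whether an amine, a carboxylic acid or a longer chain in place of propargyloxy would go beyond the scatter stays open.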